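Swapping bromine for chlorine on a bromochromene amide

The compounds below may be only part of what the source reports. "The series", "measured", "known", "first", "only" and "open" are said of these compounds alone.

Of the compounds shown here, two have been measured in an assay on HeLa cells for displacement of a labelled ligand from adenosine receptor A3 (Homo sapiens), read by scintillation counting, with a stated time of 180 min, tested at 10 uM; on this read-out higher numbers stand for more inhibition at the one concentration tested (going by the name of the read-out) and lower numbers for less inhibition. Compound 1, `N=c1oc2ccc(Br)cc2cc1C(=O)NCC(O)CO`, gives 10%. Compound 2, `CCC(CO)NC(=O)c1cc2cc(Br)ccc2oc1=N`, gives 24%. Within the data shown here, on these two numbers compound 2 stands highest, with compound 1 as its nearest neighbour; the only measured step is a number 14 percentage points higher from compound 1 to compound 2 (beyond the scatter), and it changes the group on the amide nitrogen, not the halogen on the ring.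

The next compound, compound 3, `CCC(CO)NC(=O)c1cc2cc(Cl)ccc2oc1=N`, differs from compound 2 by a change at the ring: chloro in place of bromo on an aromatic carbon. Among the measured compounds shown here, no measured step touches the halogen, so the one step in hand gives no guide to this change in this assay. Chloro and bromo are single-atom substituents with the same counts of donors and acceptors, and without data on such a swap here, the expected step is none beyond the scatter.

Compound 3 is therefore expected to give about 20% in this assay, with a likely range from 5% to 38%. This estimate means an expected step of a number 4 percentage points lower from compound 2 to compound 3 (within the scatter).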

Compound 3, a percentage reported as inhibition, at one concentration (the size of the read-out at that concentration, not a potency): 0%
Compound 3: the middle estimate sits 20 percentage points above what was measured; the measured number lies below the stated range.
By their numbers in this assay, from the lowest: compounds 3 and 1 (each within the scatter of the next); then compound 2.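

The halogen on the ring matters in this assay: the change gives a number 24 percentage points lower from compound 2 to compound 3 (beyond the scatter), so chloro and bromo do not behave as interchangeable here, even though each is a single atom with the same counts of hydrogen-bond donors and acceptors. Among these compounds, the earlier step changed only the group on the amide nitrogen, so this is the first sign that the aromatic carbon carrying the halogen can also move the reading, with the 1-(hydroxymethyl)propyl group held fixed in compound 2 and compound 3. Nothing available here explains why the two halogens differ.

This single pair cannot show how a fluoro, iodo, methyl or methoxy group on the same aromatic carbon would read, so no ranking of substituents at this position can be drawn from it. It also leaves open whether the same swap would have a similar effect with the 2,3-dihydroxypropyl group of compound 1 on the amide nitrogen, and how an amine or a longer chain at that nitrogen would read at the one concentration tested.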